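The compounds below may be only part of what the source reports. "The series", "measured", "known", "first", "only" and "open" are said of these compounds alone.

The series shares one core, shown by compound 1 `O=C1NC(=O)/C(=C/c2cn(Cc3ccccc3)c3ccccc23)N1`, which in a functional assay on NCI-H460 cells (Homo sapiens) for antiproliferative activity, read by trypan blue exclusion, with a stated time of 24 h (a lower number here means a stronger inhibitor, a higher number a weaker inhibitor), gives 14200 nM. Compound 2 `O=C1NC(=O)/C(=C/c2cn(Cc3ccc([N+](=O)[O-])cc3)c3ccccc23)N1` adds a nitro group on the benzyl ring; in this assay compound 2 records only > 40000 nM, which is a limit of the assay and not a number (the limit of > 40000 nM in this assay, at which 1 of the 3 values shown sits). That change gave an at least 2.8-fold higher number from compound 1 to compound 2 (0.44 log units; beyond the scatter). Among the measured compounds shown here, compound 3 `Cc1ccc2c(c1)c(/C=C1\NC(=O)NC1=O)cn2Cc1ccccc1` carries a methyl on the fused ring and gives 14600 nM in this assay, a step of a 1.0-fold higher number from compound 1 to compound 3 (0.01 log units; within the scatter); of the two numbers known, compound 3 holds the higher one, with compound 1 nearest and within the scatter. Compound 4 `COc1ccc2c(c1)c(/C=C1\NC(=O)NC1=O)cn2Cc1ccccc1` differs from compound 3 by methoxy in place of methyl on an aromatic carbon. For the measured compounds named here, only the step from compound 1 to compound 3 touches this position, and it stayed within the scatter; no measured step exchanges one group for another there. The expectation is therefore a step of no size beyond the scatter, a 1.0-fold higher number from compound 3 to compound 4 (0.01 log units; within the scatter). For compound 4 in this assay the estimate is 15000 nM, expected to lie between 6000 nM and 38000 nM.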

Compound 4, half-maximal inhibitory concentration: 28400 nM
The estimate for compound 4 lay 1.9-fold (0.28 log units) below the measured number, and the stated range covers the measured number.
By their numbers in this assay, from the lowest: compounds 1, 3 and 4 (each within the scatter of the next). At a limit, above all of these: compound 2.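

At this position, this assay now shows a direct exchange of one group for another: methoxy in place of methyl gives a 1.9-fold higher number from compound 3 to compound 4 (0.29 log units; within the scatter). Methoxy in place of hydrogen gives a 2.0-fold higher number from compound 1 to compound 4 (0.30 log units; within the scatter), so hydrogen, methyl and methoxy on this aromatic carbon all lie within the scatter of one another, even though methoxy brings a hydrogen-bond acceptor and methyl does not. Nothing at hand gives a cause for this result.

The compounds shown leave open whether a larger or charged group here, such as an amine, a carboxylic acid or a longer chain, would give a step beyond the scatter. They also leave open whether any group at this position could give a clearly lower number than the unsubstituted compound 1.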